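The compounds below may be only part of what the source reports. "The series", "measured", "known", "first", "only" and "open" are said of these compounds alone.

Notes on the series, aryl group on the shared core. In a functional assay on HCT-116 cells (Homo sapiens) for inhibition, read by CCK-8 assay, with a stated time of 48 h (on this read-out higher numbers stand for weaker inhibition and lower numbers for stronger inhibition), compound 3 `C=Cc1ccc(-c2cc3nccc(-c4cc(OC)c(OC)c(OC)c4)n3n2)cc1` gives 1060 nM, the middle of three numbers: compound 1 `COc1cc(-c2ccnc3cc(-c4c[nH]c5ccccc45)nn23)cc(OC)c1OC` gives 35 nM and compound 2 `COc1cc(-c2ccnc3cc(-c4ccc(Cl)cc4)nn23)cc(OC)c1OC` gives 3340 nM.

The next change leads to compound 4 `COc1ccc(-c2cc3nccc(-c4cc(OC)c(OC)c(OC)c4)n3n2)cc1N`: 3-amino-4-methoxyphenyl in place of 4-vinylphenyl on an aromatic carbon. Going by the values given here, no measured step makes this exact exchange, but three bear on it at the same place. Two are large, a 95-fold higher number from compound 1 to compound 2 (1.98 log units; beyond the scatter) and a 30-fold higher number from compound 1 to compound 3 (1.48 log units; beyond the scatter), and both replace 1H-indol-3-yl. The third is modest, a 3.2-fold lower number from compound 2 to compound 3 (0.50 log units; beyond the scatter), and stays among 4-substituted phenyl groups. The swap between chloro and vinyl therefore moved this assay much less than leaving the indole did.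

The exchange here alters the phenyl substituents more fully than that modest step, and it brings in hydrogen-bond donor and acceptor counts that 4-vinylphenyl lacks. Among the compounds with values here, the lowest number so far belongs to compound 1, the only measured compound with a hydrogen-bond donor in this group, at 35 nM. That is one compound, so the direction is only tentative. A sizeable move to a lower number is expected, probably short of the full gap to compound 1. The expected change is an 8.2-fold lower number from compound 3 to compound 4 (0.91 log units; beyond the scatter). For compound 4, the estimated value is 130 nM, with an expected range from 25 nM to 700 nM.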

Compound 4, half-maximal inhibitory concentration: 251 nM
The estimate for compound 4 lay 1.9-fold (0.29 log units) below the measured number; measured number inside the range.
By their numbers in this assay, from the lowest: compound 1; then compound 4; then compound 3; then compound 2.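

In this assay, the exchange of 4-vinylphenyl for 3-amino-4-methoxyphenyl gives a 4.2-fold lower number from compound 3 to compound 4 (0.63 log units; beyond the scatter) and, against the chlorinated analogue, a 13-fold lower number from compound 2 to compound 4 (1.12 log units; beyond the scatter), so substituents on the phenyl group can move this position further than the swap between chloro and vinyl did. Leaving 1H-indol-3-yl for this phenyl group still gives a 7.2-fold higher number from compound 1 to compound 4 (0.86 log units; beyond the scatter), a modest step where the two earlier departures from the indole were large, so much of the earlier loss does not depend on keeping the indole, though compound 1 keeps the lowest number. The order now places the two compounds with a hydrogen-bond donor in this group, compound 1 and compound 4, ahead of compound 3 and compound 2, with no compound against it among these four, and no measurement here gives a reason for the shift.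

On these data alone, the amino and methoxy groups enter together, so their separate contributions remain open. Also open, as far as these compounds go, is whether a hydroxyl in place of the amino group, or an acetamide built on it, would hold or lower the number.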